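Cytotoxicity of a Urea Series: Replacing the Oxazolidinone

A few compounds are considered here, and "the series" means these few. Any claim that something is new, unique, unknown or untested is made for them only; others in the source may bear on it.

Compound 1: `O=C1OC(c2ccccc2)CN1c1cnn2c1CN(C(=O)Nc1cc(F)c(F)c(F)c1)C(C1CC1)C2` with 7410 nM
Compound 2: `CC1CCn2ncc(N3CC(c4ccccc4)CC3=O)c2CN1C(=O)Nc1cc(F)c(F)c(F)c1` with > 2000 nM

In a toxicity assay on HepG2 2.2.15 cells (Homo sapiens) for cytotoxicity, read by CellTiter-Glo (a lower number here means that less compound is tolerated, a higher number that more compound is tolerated), compound 1 gives the only number shown. The reading for compound 2 is a limit of the assay rather than a number, (the limit of > 2000 nM in this assay, at which 1 of the 2 values shown sits). Compound 3, `O=C(Nc1cc(F)c(F)c(F)c1)N1Cc2c(-c3ccc(F)cc3)cnn2CC1C1CC1`, has not been measured in this assay. It differs from compound 1 in one place: 4-fluorophenyl in place of 2-oxo-5-phenyl-1,3-oxazolidin-3-yl on an aromatic carbon. Going by the values given here, no measured pair with a single change is available, so the size of this step in this assay is open; a step from compound 1 to compound 3 of a 1.2-fold lower number from compound 1 to compound 3 (0.09 log units; within the scatter) is expected, no larger than the usual scatter. Compound 3 is estimated at 6000 nM, between 2000 nM and 20000 nM.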

Compound 3, half-maximal cytotoxic concentration: 38500 nM
Estimate against measurement, compound 3: 6.4-fold (0.81 log units) below; measured number outside the range, above it.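

In this assay, the group on this aromatic carbon of the five-membered ring matters: 4-fluorophenyl in place of 2-oxo-5-phenyl-1,3-oxazolidin-3-yl gives a 5.2-fold higher number from compound 1 to compound 3 (0.72 log units; beyond the scatter). The oxazolidinone is therefore not needed for the series to sit at this level, and the change moves the number towards more compound being tolerated. Nothing measured here accounts for the size of this step.

Going by these compounds, whether a morpholine or a carboxylic acid on this carbon would shift the number further remains open. So does whether the same change would give a similar step on a core carrying a different group in place of the cyclopropyl.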